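The compounds below may be only part of what the source reports. "The series", "measured", "known", "first", "only" and "open" are said of these compounds alone.

Of the compounds shown here, three sharing one core have been measured in an assay for binding affinity to dual specificity mitogen-activated protein kinase kinase 4 (Homo sapiens), read by KINOMEscan, tested at 100 nM; on this read-out higher numbers stand for a weaker effect at the one concentration tested and lower numbers for a stronger effect. Compound 1 `CCCS(=O)(=O)Nc1ccc(F)c(C(=O)c2n[nH]c3ncc(-c4cccc(C)c4)cc23)c1F` gives 15%. Compound 2 `CCCS(=O)(=O)Nc1ccc(F)c(C(=O)c2n[nH]c3ncc(-c4ccc(N)cc4)cc23)c1F` gives 0.1%, and compound 3 `CCCS(=O)(=O)Nc1ccc(F)c(C(=O)c2n[nH]c3ncc(-c4ccc(N(C)C)cc4)cc23)c1F` gives 2.5%. Compound 3 stands second highest of the three: it sits a number 2.4 percentage points higher from compound 2 to compound 3 (within the scatter), and compound 1 sits a number 12.5 percentage points lower from compound 1 to compound 3 (beyond the scatter).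

Compound 4 `CCCS(=O)(=O)Nc1ccc(F)c(C(=O)c2n[nH]c3ncc(-c4ccc(Cl)cc4Cl)cc23)c1F` has not yet been measured. It differs from compound 3 in one place: 2,4-dichlorophenyl in place of 4-(dimethylamino)phenyl on an aromatic carbon.

Among the compounds with values here, no measured step swaps the whole pendant ring for a dichlorophenyl, so the guidance is indirect. The two steps that exchange the pendant ring, a number 14.9 percentage points lower from compound 1 to compound 2 (beyond the scatter) and a number 12.5 percentage points lower from compound 1 to compound 3 (beyond the scatter), show that such an exchange can shift the read-out by a modest amount, while the smaller swap a number 2.4 percentage points higher from compound 2 to compound 3 (within the scatter) stayed within the scatter. Within the data shown here, the exchange to compound 4 removes the single acceptor that compounds 2 and 3 carry on this ring, making compound 4 in that respect more like compound 1. A move back toward the value of compound 1 is therefore expected, though with wide uncertainty. The expected step is a number 7.5 percentage points higher from compound 3 to compound 4 (within the scatter). For compound 4 the estimate in this assay is 10%, with a range from 0.5% to 45%.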

Compound 4, a percentage reported as activity, at one concentration (the size of the read-out at that concentration, not a potency): 22%
Estimate against measurement, compound 4: 12 percentage points below; low and high end bracket the measured number.
By their numbers in this assay, from the lowest: compounds 2 and 3 (each within the scatter of the next); then compounds 1 and 4 (each within the scatter of the next).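

At this position on the shared core, this assay now divides the four pendant rings into two groups. Compared with the nitrogen-bearing rings, 2,4-dichlorophenyl gives a number 19.5 percentage points higher from compound 3 to compound 4 (beyond the scatter) and a number 21.9 percentage points higher from compound 2 to compound 4 (beyond the scatter), so both exchanges exceed what the smaller step among the earlier compounds showed. Against the other ring without nitrogen, it gives a number 7 percentage points higher from compound 1 to compound 4 (within the scatter), so these four compounds do not separate 2,4-dichlorophenyl from 3-methylphenyl, and no measurement here explains the split between the two groups.

From the compounds shown here alone, with two chlorines entering at once, the contribution of each remains unknown, and a phenyl ring carrying a single chlorine would help separate them. Going by these compounds, it also remains open whether a nitrogen-free ring bearing a methoxy group, or a ring bearing a carboxylic acid, would fall with either group.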